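Working notes on a short oxindole hydroxamate series

The source may report more compounds than this note shows. Statements on the series, on what has been measured and on what is new or still open speak of the compounds shown alone.

Among the compounds with values here, the series so far holds two measured compounds. Compound 1 `COc1ccc2c(c1)/C(=C1/Nc3ccccc3/C1=N\O)C(=O)N2Cc1ccc(/C=C/C(=O)NO)cc1` and compound 2 `O=C(/C=C/c1ccc(CN2C(=O)/C(=C3\Nc4ccccc4\C3=N/O)c3cccc(Cl)c32)cc1)NO` carry the same hydroxamic acid side chain and differ only in the substituent on the shared core. In a functional assay on NCI-H23 cells (Homo sapiens) for cytotoxicity, read by colorimetric assay (a higher number here means a weaker inhibitor, a lower number a stronger inhibitor), compound 1 gives 50 nM, and in this assay compound 2 gives 50 nM. Compound 2 thus stands level with compound 1 within the scatter; no ordering between the two is supported.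

Compound 3 `O=C(NO)c1ccc(CN2C(=O)/C(=C3\Nc4ccccc4\C3=N/O)c3cccc(Cl)c32)cc1` is not yet measured. It differs from compound 2 in one place: hydroxycarbamoyl in place of 2-(hydroxycarbamoyl)ethenyl on an aromatic carbon. Within the data shown here, no step between measured compounds covers a change of this kind, so no measured step size is available to anchor it. From compound 2 to compound 3, a modest loss in this assay is expected, a 3.0-fold higher number from compound 2 to compound 3 (0.48 log units; beyond the scatter), though a result within the scatter cannot be excluded. Compound 3 is therefore estimated at 150 nM, within a range from 40 nM to 600 nM.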

Compound 3, half-maximal inhibitory concentration: 60 nM
Compound 3: the middle estimate sits 2.5-fold (0.40 log units) above what was measured; measured number inside the range.
By their numbers in this assay, from the lowest: compounds 1, 2 and 3 (each within the scatter of the next).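

In this assay, hydroxycarbamoyl in place of 2-(hydroxycarbamoyl)ethenyl, on an aromatic carbon para to a large group, gives a 1.2-fold higher number from compound 2 to compound 3 (0.08 log units; within the scatter) and so leaves the reading unmoved. Within the data shown here, compounds 1 and 2 kept this group fixed and differed only on the shared core, so this is the first reading at this position: the change from a group of 6 heavy atoms with 2 double bonds to one of 4 heavy atoms with 1 double bond has no visible effect on the number in this cell assay. Nothing at hand bears on why the number holds across this change.

As far as these compounds go, whether the number also holds with a longer chain ending in the hydroxamic acid, or with a carboxylic acid or an amine on this aromatic carbon, remains open. Also open, from the compounds shown here alone, is whether the same change on the core of compound 1 would give a step of similar size.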